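The source may report more compounds than this note shows. Statements on the series, on what has been measured and on what is new or still open speak of the compounds shown alone.

Measured so far in an ADME assay on NCM460 cells (Homo sapiens) for cytotoxicity, read by MTT assay, with a stated time of 72 h; a lower number here means a stronger inhibitor, a higher number a weaker inhibitor:
compound 1 `Cc1ccc(N2C(=O)C/C(=C\c3cccc(C(=O)Nc4cccc(F)c4)c3)C2=O)cc1` gives a limit, > 100000 nM.
compound 2 `COc1ccc(NC(=O)c2cccc(/C=C3\CC(=O)N(c4ccc(C)cc4)C3=O)c2)cc1` gives a limit, > 100000 nM.
compound 3 `CCCCCN1C(=O)C/C(=C\c2cccc(C(=O)Nc3ccc(OC)cc3)c2)C1=O` gives a limit, > 100000 nM.

All three values are limits of this assay, not numbers, and they coincide with the limit of > 100000 nM in this assay, at which 3 of the 3 values shown sit. Compound 2 and compound 1 differ by 3-fluorophenyl in place of 4-methoxyphenyl on an amide-type nitrogen, and the step that the two limits leave unreadable from compound 2 to compound 1 cannot be read because both sit at a limit. Compound 2 and compound 3 differ in their cores by pentyl in place of 4-methylphenyl on an amide-type nitrogen in a ring, and the step that the two limits leave unreadable from compound 2 to compound 3 is likewise unreadable for the same reason.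

Compound 4 `CCCCCN1C(=O)C/C(=C\c2cccc(C(=O)Nc3cccc(F)c3)c2)C1=O` is not yet measured in this assay. It differs from compound 3 by 3-fluorophenyl in place of 4-methoxyphenyl on an amide-type nitrogen, the same change that turns compound 2 into compound 1, at the same place on an amide-type nitrogen. Since that earlier step could not be read and compound 3 itself sits at the limit (the limit of > 100000 nM in this assay, at which 3 of the 3 values shown sit), no direction for this change is known from these three compounds. The step that the limit leaves unreadable from compound 3 to compound 4 is expected to be small, resting on the earlier unreadable step that the two limits leave unreadable from compound 2 to compound 1. Compound 4 is estimated at 150000 nM, within 80000 nM to 400000 nM, most likely reported again only as a limit.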

Compound 4, half-maximal inhibitory concentration: > 100000 nM
Compound 4 ended at the assay's limit; the forecaster's own chance of this, stated with the estimate: 90%; the middle value lies beyond the limit too.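

In this assay compound 4 gives > 100000 nM, a limit and not a number. Neither its step from compound 3 nor its step from compound 1 can be read, because all four compounds sit at the same limit: the limit of > 100000 nM in this assay, at which 4 of the 4 values shown sit.

The compounds shown leave open whether replacing 4-methoxyphenyl with 3-fluorophenyl, or 4-methylphenyl with pentyl, changes the result in this assay at all.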